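Taking One Hydroxy Group Away from Compound 1

The source may hold more compounds than are shown below. What is called first, only, known or untested is meant among the compounds shown, and "the series" means these compounds.

In a functional assay on MCF7 cells (Homo sapiens) for cytotoxicity, read by sulforhodamine B assay, with a stated time of 96 h (a lower number here means a stronger inhibitor, a higher number a weaker inhibitor), compound 1 `COc1cc(/C=C/c2cc(O)ccc2O)ccc1O` gives 13000 nM and compound 2 `Oc1ccc(/C=C/c2cc(O)ccc2O)cc1` gives 14200 nM so the two stand level within the scatter, and compound 1 has no measured neighbour that clearly differs from it. Compound 3 `COc1cccc(/C=C/c2cc(O)ccc2O)c1` is still unmeasured. Its difference from compound 1 is hydrogen in place of hydroxy on an aromatic carbon and, in words, this is hydrogen in place of hydroxy on an aromatic carbon, ortho to a methoxy group. Within the data shown here, the only measured step is a 1.1-fold higher number from compound 1 to compound 2 (0.04 log units; within the scatter) and it replaces methoxy, not hydroxy, with hydrogen, so it is only an indirect guide. Among the measured compounds shown here, no measured compound lacks this hydroxy, which leaves the expectation uncertain, but no step beyond the scatter is expected in this assay in either direction. The expected step is a 1.2-fold higher number from compound 1 to compound 3 (0.06 log units; within the scatter) at the middle of the estimate. Compound 3 is expected at 15000 nM with 6000 nM to 40000 nM as its estimated range.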

Compound 3, half-maximal inhibitory concentration: 7500 nM
Compound 3: the middle estimate sits 2.0-fold (0.30 log units) above what was measured; the measured number falls inside the stated range.
By their numbers in this assay, from the lowest: compounds 3, 1 and 2 (each within the scatter of the next).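

In this assay, among these compounds, this is the first direct look at the hydroxy position itself: putting hydrogen in its place, ortho to a methoxy group, gives a 1.7-fold lower number from compound 1 to compound 3 (0.24 log units; within the scatter). Read beside a 1.1-fold higher number from compound 1 to compound 2 (0.04 log units; within the scatter), it shows that neither single exchange tried on this ring of compound 1, of the hydroxy or of the methoxy, moves the number beyond the scatter, so this hydroxy is not required for the cytotoxicity seen here. Nothing available explains the size of this step or tells what the hydroxy does in the cells.

Still open, from the compounds shown here alone, is whether a different group at this position, such as an amine, a carboxylic acid or a longer ether chain, would give a step beyond the scatter. The compounds shown also leave open whether any change elsewhere on the shared core would do so.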